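Benzimidazole to a single-nitrogen bicycle on the butyl chain

The source may hold more compounds than are shown below. What is called first, only, known or untested is meant among the compounds shown, and "the series" means these compounds.

Measured compounds:
compound 1 `Cc1nc2ccccc2n1CCCCN1CCN(C(c2ccccc2)c2ccccc2)CC1` gives 850 nM in an assay on RPMI-8226 cells for antagonist activity at P2X purinoceptor 7 (Homo sapiens), read by calcium flux; a lower number here means a stronger inhibitor, a higher number a weaker inhibitor
compound 2 `Cc1cc2ncn(CCCCN3CCN(C(c4ccccc4)c4ccccc4)CC3)c2cc1C` gives 770 nM in this assay

Among the compounds with values here, compound 2 holds the lowest of the two numbers so far, though the gap to compound 1 is small: a 1.1-fold lower number from compound 1 to compound 2 (0.04 log units; within the scatter). That step says the swap of one methylated bicycle for another, at the chain end four bonds from the ring amine nitrogen, leaves the read-out where it was.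

Compound 3 `Cc1cccc2c1ccn2CCCCN1CCN(C(c2ccccc2)c2ccccc2)CC1` is the next point on the same chain position. The change is a group of 10 heavy atoms (9 carbon, 1 nitrogen; one five-membered aromatic ring with 1 hetero atom, one six-membered aromatic ring of carbon only) in place of a group of 11 heavy atoms (9 carbon, 2 nitrogen; one five-membered aromatic ring with 2 hetero atoms, one six-membered aromatic ring of carbon only), on a saturated chain carbon, four bonds along the chain from an amine nitrogen in a ring. Within the data shown here, only the step from compound 1 to compound 2 bears on this change, and it was within the scatter. That step kept both ring nitrogens, whereas the present change removes one hetero atom and one acceptor, so the precedent is only partial. Nothing measured here speaks for a gain; the plausible outcome is no change beyond the scatter, or a modest loss. The expected step of a 1.2-fold higher number from compound 2 to compound 3 (0.09 log units; within the scatter) is therefore a small rise in the number.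

Compound 3 is estimated at 950 nM in this assay, with a range of 350 nM to 2600 nM.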

Compound 3, half-maximal inhibitory concentration: 5300 nM
Estimate against measurement, compound 3: 5.6-fold (0.75 log units) below; measured number outside the range, above it.
By their numbers in this assay, from the lowest: compounds 2 and 1 (each within the scatter of the next); then compound 3.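

In this assay the bicycle at this place on the chain does matter: the read-out stayed flat only while both ring nitrogens were kept, and the change to the group with one hetero atom gives a 6.9-fold higher number from compound 2 to compound 3 (0.84 log units; beyond the scatter). The rise also appears against the other neighbour, as a 6.2-fold higher number from compound 1 to compound 3 (0.79 log units; beyond the scatter), even though both groups in that pair hold 10 heavy atoms, so heavy-atom count alone does not follow the read-out across these three compounds. The entering group also differs from both leaving groups in its methyl substitution, so the loss of a hetero atom cannot be separated from the methyl pattern, and no measurement at hand offers a reason for the rise.

Still open, on these data alone, is whether the rise tracks the hetero atom itself, which a pair differing only in that atom, with the methyl pattern held fixed, would settle. Also open, as far as these compounds go, is how a 1H-benzotriazol-1-yl group at the same chain end, or a pentyl chain in place of the butyl chain, would read in this assay.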